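Compound 4: Bromophenyl in Place of Methoxyphenyl

This account rests on a few compounds, and the source may have more. Where it says the series, first, only, none or still open, it means among the compounds named here.

Measured so far in a functional assay on HepG2 cells (Homo sapiens) for inhibition, read by MTT assay, with a stated time of 24 h; on this read-out lower numbers stand for stronger inhibition and higher numbers for weaker inhibition:
compound 1, `CC1(C)[C@H]2CC[C@]1(C)N(Cc1cn(-c3ccccc3O)nn1)C(=O)C2`: 120 nM
compound 2, `COc1ccccc1-n1cc(CN2C(=O)C[C@@H]3CC[C@@]2(C)C3(C)C)nn1`: 110 nM
compound 3, `COc1ccc(-n2cc(CN3C(=O)C[C@@H]4CC[C@@]3(C)C4(C)C)nn2)cc1`: 100 nM

All three share one core and differ only in the aryl group on the aromatic nitrogen. Compound 3 has the lowest of the three numbers, yet both gaps to it are within the scatter: a 1.1-fold lower number from compound 2 to compound 3 (0.04 log units; within the scatter), and a 1.2-fold lower number from compound 1 to compound 3 (0.08 log units; within the scatter). The third step, a 1.1-fold lower number from compound 1 to compound 2 (0.04 log units; within the scatter), is likewise within the scatter, so across these compounds the aryl group has not moved the read-out in this assay.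

Compound 4, `CC1(C)[C@H]2CC[C@]1(C)N(Cc1cn(-c3ccccc3Br)nn1)C(=O)C2`, is the next compound, differing from compound 3 by 2-bromophenyl in place of 4-methoxyphenyl on an aromatic nitrogen. Within the data shown here, the three measured steps bear on it only insofar as they all change this same aryl group, and each stayed within the scatter; none of them introduces bromine, so no direct precedent exists. Compound 4 is therefore expected to stay close to compound 3, with a 1.1-fold higher number from compound 3 to compound 4 (0.04 log units; within the scatter) and an estimated value of 110 nM, in the range 50 nM to 250 nM.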

Compound 4, half-maximal inhibitory concentration: 150 nM
For compound 4 the middle estimate is 1.4-fold (0.13 log units) below the measured one; the measured number falls inside the stated range.
By their numbers in this assay, from the lowest: compounds 3, 2, 1 and 4 (each within the scatter of the next).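

Bromo, the first halogen in this series, leaves the read-out in this assay unchanged within the scatter when it takes the place of the other groups on the same aromatic carbon, with a 1.4-fold higher number from compound 2 to compound 4 (0.13 log units; within the scatter) against methoxy and a 1.3-fold higher number from compound 1 to compound 4 (0.10 log units; within the scatter) against hydroxy. Even the step that exchanges 4-methoxyphenyl for 2-bromophenyl, a 1.5-fold higher number from compound 3 to compound 4 (0.18 log units; within the scatter), stays within the scatter, so this position on the aromatic nitrogen has now tolerated a hydrogen-bond acceptor, a donor and a group with neither without a clear change. No measured evidence is available to account for these small steps.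

As far as these compounds go, it remains open whether an amine, a carboxylic acid or a longer chain on this aryl ring would move the number beyond the scatter. Equally open, from the compounds shown here alone, is what a simple methyl in place of the whole aryl group would do, and how changes to the shared core would read.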